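The compounds below may be only part of what the source reports. "The series", "measured", "known", "first", "only" and "open" are said of these compounds alone.

Measured compounds:
compound 1 `O=C1/C(=C/c2ccccc2)CCC/C1=C\c1cccc(O)c1`: 65.1%
compound 2 `O=C(/C=C(O)/C=C/c1ccc(O)cc1)c1ccccc1O`: 20.4%
compound 3 `O=C1/C(=C/c2ccccc2)CCC/C1=C\c1ccc(O)c(O)c1`: 90.7%

The three compounds were tested in an assay on isolated protein for inhibition of Alpha glucosidase (Homo sapiens), with stated times of 5 min and 15 min, tested at 50 uM; a lower number here means less inhibition, a higher number more inhibition at the concentration tested (going by the name of the read-out). In this assay compound 3 gives 90.7%, compound 1 gives 65.1%, and compound 2 gives 20.4%, the lowest of the three numbers, with its gaps to both other compounds lying beyond the usual scatter.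

Compound 1 and compound 3 differ in one place, (hydroxy in place of hydrogen on an aromatic carbon), and the step is a number 25.6 percentage points higher from compound 1 to compound 3 (beyond the scatter). Compound 2 carries a different core from compound 1; how the two cores differ is not broken down here.

Compound 4 `O=C(/C=C(O)/C=C/c1ccc(O)c(O)c1)c1ccccc1O` has not yet been measured. It stands to compound 2 as compound 3 stands to compound 1: the change is hydroxy in place of hydrogen on an aromatic carbon. The two places are not the same word for word: in compound 3 the new hydroxy sits para to a large group, whereas in compound 4 it sits meta to a large group, so this is the same kind of change rather than the same change. Since the earlier hydroxy gave the step of a number 25.6 percentage points higher from compound 1 to compound 3 (beyond the scatter), the account expects a step of comparable size from compound 2 to compound 4, a number 24.6 percentage points higher from compound 2 to compound 4 (beyond the scatter), estimated on that single precedent alone. Compound 4 is therefore expected to reach about 45% in this assay, within a range from 25% to 65%.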

Compound 4, a percentage reported as inhibition, at one concentration (the size of the read-out at that concentration, not a potency): 93.6%
Beside the measured number, compound 4's estimate is 48.6 percentage points below it, and the stated range ends below it.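

In this assay, hydroxy in place of hydrogen on an aromatic carbon moves the number the same way on both cores, giving a number 25.6 percentage points higher from compound 1 to compound 3 (beyond the scatter) on the first core and a number 73.2 percentage points higher from compound 2 to compound 4 (beyond the scatter) on the second. The direction of the change therefore carries from one core to the other in this pair of steps, but its size does not: the same change on two cores in this assay, a number 25.6 percentage points higher (beyond the scatter) from compound 1 to compound 3 and a number 73.2 percentage points higher (beyond the scatter) from compound 2 to compound 4, 47.6 percentage points apart, beyond the scatter of two such steps This does not show that the core alone sets the size of the step, as the new hydroxy does not stand in the same relation to the large group in the two pairs, and with a single pair on each core the two possible sources of the gap cannot be told apart; the numbers are also percentages at one concentration rather than potencies, so they give no measure of how potency shifts.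

The compounds shown leave open whether a methoxy group or an amine on that same aromatic carbon would give a step like either of these. They also leave open how the hydroxy would behave on a third core, so no size can yet be assigned to this change beyond these two pairs.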